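This account rests on a few compounds, and the source may have more. Where it says the series, first, only, none or still open, it means among the compounds named here.

Within the data shown here, compound 1, with the structure `CCC(OC)C1=C(N2CC2)C(=O)C(C)=C(N2CC2)C1=O`, is the weaker of the two compounds measured so far in a functional assay on L1210 cells (Mus musculus), with a stated time of 1 days; on this read-out lower numbers stand for lower potency and higher numbers for higher potency (the scale is a negative logarithm): compound 1 gives 5.26 there. Among the measured compounds shown here, its companion, compound 2 with the structure `CCC(COC(N)=O)C1=C(N2CC2)C(=O)C(C)=C(N2CC2)C1=O`, gives 6.03 in this assay, and the single change between them, a (carbamoyloxy)methyl in place of methoxy on a saturated chain carbon bound to a double-bonded ring carbon and a saturated chain carbon, brings a number 0.77 log units higher from compound 1 to compound 2 (beyond the scatter).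

Compound 3, with the structure `CC1=C(N2CC2)C(=O)C(CCCOC(N)=O)=C(N2CC2)C1=O`, has not yet been measured in this assay. Compared with compound 1 it carries a group of 7 heavy atoms (4 carbon, 1 nitrogen, 2 oxygen; no ring) in place of a group of 5 heavy atoms (4 carbon, 1 oxygen; no ring), on a double-bonded ring carbon. For the measured compounds named here, the one step on record, from compound 1 to compound 2, is the only guide here: it introduced a carbamate group and was followed by a modest gain. Because that step was a number 0.77 log units higher from compound 1 to compound 2 (beyond the scatter), a gain of similar size is expected for compound 3, giving an estimated step of a number 0.64 log units higher from compound 1 to compound 3 (beyond the scatter). Compound 3 is therefore expected to reach about 5.9 in this assay, within a range from 5.4 to 6.4.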

Compound 3, logarithm of the reciprocal of the active concentration, log(1/C): 5.55
The estimate for compound 3 lay 0.35 log units above the measured number; the measured number falls inside the stated range.
By their numbers in this assay, from the lowest: compounds 1 and 3 (each within the scatter of the next); then compound 2.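

In this assay the change at this double-bonded ring carbon gives a number 0.29 log units higher from compound 1 to compound 3 (within the scatter) and so cannot be told apart from no change at all. Compound 2 had tied a carbamate to a gain beyond the scatter, but compound 3 also carries a carbamate and shows no such gain over compound 1, so the presence of this group is not enough on its own for a readable gain. No measurement at hand explains this result. The compounds shown leave open whether a longer chain ending in the same carbamate would lift the number beyond the scatter from compound 1. They also leave open what an amine or a carboxylic acid at the end of the chain, in place of the carbamate, would do.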